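From cyano to diethylcarbamoyl on the shared core

A few compounds are considered here, and "the series" means these few. Any claim that something is new, unique, unknown or untested is made for them only; others in the source may bear on it.

In a functional assay on the whole organism with Rattus norvegicus as the target (a higher number here means that more compound is needed for the effect, a lower number that less compound is needed), compound 1 `Nc1nc2ccc(I)cc2s1` reports only a limit, > 10 mg/kg. Compound 2 `C#CCn1c(=N)sc2cc(OC(F)(F)F)ccc21` gives 4 mg/kg, and compound 3 `N#CCn1c(=N)sc2cc(OC(F)(F)F)ccc21` gives 3.5 mg/kg. For the measured compounds named here, these two numbers lie within the scatter of each other, so compound 3 stands level with compound 2, the only other number available.

Compound 4 `CCN(CC)C(=O)Cn1c(=N)sc2cc(OC(F)(F)F)ccc21` has not yet been measured. It differs from compound 3 as follows: diethylcarbamoyl in place of cyano on a saturated chain carbon bound to an aromatic nitrogen. Going by the values given here, one measured step bears on this place, with cyano in place of ethynyl: a 1.1-fold lower number from compound 2 to compound 3 (0.06 log units; within the scatter). Among the compounds with values here, that step stays within the scatter, but no measured compound carries diethylcarbamoyl, so it offers only weak guidance.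

What is expected in this assay is a 1.4-fold higher number from compound 3 to compound 4 (0.15 log units; within the scatter), an estimated small rise that may not clear the scatter. For compound 4 the estimated value is 5 mg/kg, with an expected range from 1.8 mg/kg to 15 mg/kg.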

Compound 4, dose for half-maximal effect: 9 mg/kg
Compound 4: middle estimate off by 1.8-fold (0.26 log units), on the low side; low and high end bracket the measured number.
By their numbers in this assay, from the lowest: compounds 3 and 2 (each within the scatter of the next); then compound 4. At a limit, above all of these: compound 1.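

For the compounds shown here, at the saturated chain carbon bound to an aromatic nitrogen, the earlier compounds showed no change beyond the scatter in this assay, and diethylcarbamoyl is the first group there to shift the number: a 2.6-fold higher number from compound 3 to compound 4 (0.41 log units; beyond the scatter) and a 2.3-fold higher number from compound 2 to compound 4 (0.35 log units; beyond the scatter) in the same direction. The place is therefore not indifferent to what it carries, since cyano and ethynyl stand level while diethylcarbamoyl requires more compound for the effect. Nothing measured here gives a reason for this rise.

The compounds shown leave open whether the rise belongs to the amide as such or to its two ethyl groups, since neither a primary amide nor a dimethylamide stands among them. They also leave open how an amine or a carboxylic acid at this place would compare with compound 3.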